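The source may hold more compounds than are shown below. What is called first, only, known or untested is meant among the compounds shown, and "the series" means these compounds.

Working notes on the series in a functional assay on A549 cells (Homo sapiens) for antiproliferative activity, read by MTT assay, with a stated time of 72 h; a higher number here means a weaker inhibitor, a lower number a stronger inhibitor. Compound 1 `COc1ncc(-c2ccc3c(c2)N(C2CCCCC2)C(=O)CO3)cc1NS(=O)(=O)c1ccc(F)cc1` gives 24600 nM and compound 2 `O=C1COc2ccc(-c3cccc(NS(=O)(=O)c4ccc(F)cc4)c3)cc2N1c1ccc(Cl)cc1` gives 31600 nM, two values within the scatter of each other. Compound 3 `Cc1ccc(N2C(=O)COc3ccc(-c4cnc5ccccc5c4)cc32)cc1` reads > 40000 nM, which is a limit of the assay and not a number. Compound 2 therefore stands level with compound 1 on the numbers available.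

Compound 4 `O=C1COc2ccc(-c3cccc(NS(=O)(=O)c4ccc(F)cc4)c3)cc2N1c1ccc(F)cc1` departs from compound 2 at one place: fluoro in place of chloro on an aromatic carbon. This is fluoro in place of chloro on an aromatic carbon, para to a large group, so that 4-chlorophenyl becomes 4-fluorophenyl. Within the data shown here, no two measured compounds here differ at one place only, so the series offers no measured step as a guide. With compound 2 at 31600 nM, no change beyond the scatter is expected in this assay, in either direction. The estimated 1.1-fold lower number from compound 2 to compound 4 (0.02 log units; within the scatter) is accordingly small. For compound 4 the expected value is 30000 nM, with an estimated range from 15000 nM to 40000 nM.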

Compound 4, half-maximal inhibitory concentration: > 40000 nM
Compound 4: a limit, no number; the forecaster's own chance of this, stated with the estimate: 25%; middle value at least 1.3-fold (0.12 log units) away from the limit.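

In this assay, among these compounds, the change from 4-chlorophenyl to 4-fluorophenyl gives the only measured step at one place: an at least 1.2-fold higher number from compound 2 to compound 4 (0.10 log units; that floor lies within the scatter). Compound 4 reads > 40000 nM, which is a limit of the assay and not a number, so the step has a floor but no readable size. The change at this position, on an aromatic carbon para to a large group, therefore brings no measurable strengthening, and the reading stops at the limit of the assay: the limit of > 40000 nM in this assay, at which 2 of the 4 values shown sit.

Going by these compounds, whether compound 4 truly differs from compound 2 by more than the scatter stays open. Also open, on these data alone, is how an amine or a carboxylic acid in place of the halogen at this position would read in this assay.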